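A few compounds are considered here, and "the series" means these few. Any claim that something is new, unique, unknown or untested is made for them only; others in the source may bear on it.

Measured compounds:
- compound 1, `COc1cc(/C=C/C(=O)c2cccc(-n3cc(-c4ccc(Cl)cc4)[nH]c3=O)c2)cc(OC)c1OC`: 7380 nM
- compound 2, `COc1cc(/C=C/C(=O)c2cccc(-n3cc(-c4ccccc4)[nH]c3=O)c2)ccc1O`: 2210 nM

Two compounds of the series have been run in a functional assay on COLO 205 cells (Homo sapiens) for inhibition; on this read-out lower numbers stand for stronger inhibition of growth and higher numbers for weaker inhibition of growth. Compound 1 `COc1cc(/C=C/C(=O)c2cccc(-n3cc(-c4ccc(Cl)cc4)[nH]c3=O)c2)cc(OC)c1OC` gives 7380 nM in this assay. Compound 2 `COc1cc(/C=C/C(=O)c2cccc(-n3cc(-c4ccccc4)[nH]c3=O)c2)ccc1O` gives 2210 nM in this assay and so stands at the lowest of the two numbers; the gap to compound 1 lies beyond the scatter, so compound 2 is the stronger of the two. Within the data shown here, the two differ in more than one place, so no single step between them can be read.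

The next compound is compound 3 `O=C(/C=C/c1cccc(O)c1)c1cccc(-n2cc(-c3ccccc3)[nH]c2=O)c1`, which has not yet been measured in this assay. Relative to compound 2 the change is 3-hydroxyphenyl in place of 4-hydroxy-3-methoxyphenyl on a double-bonded chain carbon bound to a double-bonded chain carbon. Among the measured compounds shown here, no measured pair shows this change on its own, so the direction is open. A modest step is expected, most likely toward a somewhat higher number, but one that could well stay within the scatter; the expected step is a 1.4-fold higher number from compound 2 to compound 3 (0.16 log units; within the scatter). For compound 3 the estimate in this assay is 3200 nM, with a range from 1100 nM to 9500 nM.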

Compound 3, concentration for 50% growth inhibition: 2010 nM
The estimate for compound 3 lay 1.6-fold (0.20 log units) above the measured number; the range from low to high includes it.
By their numbers in this assay, from the lowest: compounds 3 and 2 (each within the scatter of the next); then compound 1.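

In this assay, 3-hydroxyphenyl in place of 4-hydroxy-3-methoxyphenyl on a double-bonded chain carbon bound to a double-bonded chain carbon gives a 1.1-fold lower number from compound 2 to compound 3 (0.04 log units; within the scatter) and so leaves the read-out unmoved at this position. The entering group has 7 heavy atoms and 1 hydrogen-bond acceptor against 9 heavy atoms and 2 hydrogen-bond acceptors in the group it replaces, so in this one pair, neither those extra atoms nor the shift to 3-hydroxyphenyl shows up in the growth-inhibition number. No measurement at hand speaks to what lies behind this result.

On these data alone, whether this position stays as flat with a different kind of group, such as 3-aminophenyl or 3-carboxyphenyl on the same chain carbon, remains open, since both compounds in this pair carry a hydroxyphenyl there. Compound 1 differs from compound 2 and from compound 3 in more than one place, so steps to it cannot be read, and the separate contributions of its trimethoxy-substituted ring and its chlorine-bearing phenyl to the growth-inhibition number stay unresolved.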